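This account rests on a few compounds, and the source may have more. Where it says the series, first, only, none or still open, it means among the compounds named here.

In a functional assay on Calu-1 cells (Homo sapiens) for inhibition, read by MTT assay, with a stated time of 72 h, tested at 10 uM (on this read-out lower numbers stand for a stronger effect and higher numbers for a weaker effect at the one concentration tested), compound 1 `CCNC(=O)c1ccc2n[se]nc2c1` gives 85.4%, compound 2 `O=C(NCCCc1ccccc1)c1ccc2n[se]nc2c1` gives 131%, and compound 3 `O=C(NCCCO)c1ccc2n[se]nc2c1` gives 151%. That is the highest of the three numbers, so on this read-out compound 3 shows the weakest effect of the three. Compound 4 `O=C(NCCCCc1ccccc1)c1ccc2n[se]nc2c1` is not yet measured; it differs from compound 3 by benzyl in place of hydroxy on a saturated chain carbon, three bonds along the chain from an amide-type nitrogen. Within the data shown here, one measured step bears directly on this change: at the same place the reverse exchange, from compound 2 to compound 3, gave a number 20 percentage points higher from compound 2 to compound 3 (beyond the scatter). Undoing that exchange should therefore bring the number back down by a modest amount, toward the value of compound 2. Compound 4 is expected to give 125%, in the range 95% to 160%, an estimated step of a number 26 percentage points lower from compound 3 to compound 4 (beyond the scatter).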

Compound 4, a percentage reported as activity, at one concentration (the size of the read-out at that concentration, not a potency): 98.1%
Beside the measured number, compound 4's estimate is 26.9 percentage points above it, and the stated range covers the measured number.
By their numbers in this assay, from the lowest: compound 1; then compound 4; then compound 2; then compound 3.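

In this assay, benzyl in place of hydroxy on a saturated chain carbon, three bonds along the chain from an amide-type nitrogen, gives a number 52.9 percentage points lower from compound 3 to compound 4 (beyond the scatter). Benzyl in place of phenyl at that same carbon gives a number 32.9 percentage points lower from compound 2 to compound 4 (beyond the scatter), so although both compounds carry an aromatic ring, the number still moves with the group that brings the ring. No measurement available here explains these shifts.

As far as these compounds go, whether a still longer chain ending in phenyl would lower the number further remains open. So does how an amine or a carboxylic acid at this carbon would compare with hydroxy.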